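Swapping methyl for oxetan-3-yl on a sulfonyl sulfur

This account rests on a few compounds, and the source may have more. Where it says the series, first, only, none or still open, it means among the compounds named here.

Measured in an ADME assay on microsomes from liver (Homo sapiens) for metabolic stability; a lower number here means slower removal, a higher number faster removal of the compound:
- compound 1 `CCn1cnc2c(-c3ccc(F)c(-c4ccc(C(=O)NC)cc4)c3)cnnc21`: 16 mL.min-1.g-1
- compound 2 `CCc1cnn2c(-c3ccc(F)c(-c4ccc(S(=O)(=O)CC)cc4)c3)ccnc12`: 30 mL.min-1.g-1
- compound 3 `CCn1cnc2c(-c3ccc(F)c(-c4ccc(S(C)(=O)=O)cc4OC)c3)cnnc21`: < 8 mL.min-1.g-1

Compound 3 has no exact number and stands at the limit of < 8 mL.min-1.g-1 in this assay, at which 1 of the 3 values shown sits. Its true clearance is therefore known only as a limit. Compound 1 and compound 2 both gave numbers, and these lie within the usual scatter of each other.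

The account now turns to compound 4 `CCn1cnc2c(-c3ccc(F)c(-c4ccc(S(=O)(=O)C5COC5)cc4OC)c3)cnnc21`, in which oxetan-3-yl takes the place of methyl on a sulfonyl sulfur (oxetan-3-yl in place of methyl on a sulfonyl sulfur). Among the compounds with values here, no measured pair in this set differs in one place only, so the data do not size this change directly. The estimated step of an at least 1.1-fold higher number from compound 3 to compound 4 (0.05 log units; that floor lies within the scatter) is expected to point slightly towards faster removal and to stay within the scatter. The estimate in this assay for compound 4 is 9 mL.min-1.g-1, with an expected range of 5 mL.min-1.g-1 to 20 mL.min-1.g-1. The assay could also report only a limit again.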

Compound 4, intrinsic clearance in microsomes: 67 mL.min-1.g-1
Compound 4: middle estimate off by 7.4-fold (0.87 log units), on the low side, outside the stated range (above it).
By their numbers in this assay, from the lowest: compounds 1 and 2 (each within the scatter of the next); then compound 4. At a limit, below all of these: compound 3.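

In this assay, within the data shown here, oxetan-3-yl in place of methyl on a sulfonyl sulfur gives an at least 8.3-fold higher number from compound 3 to compound 4 (0.92 log units; beyond the scatter), the first step in this set between two compounds that differ in one place. It shows that, with the rest of the structure held constant, the group on this sulfur can by itself shift the clearance beyond the usual scatter, towards faster removal. The true size of the step remains a floor, as compound 3 has no exact number and is known only as a limit: the limit of < 8 mL.min-1.g-1 in this assay, at which 1 of the 4 values shown sits.

A single step cannot tell whether the four-membered ring, its oxygen or the larger group as a whole accounts for the shift. The compounds shown also leave open how a cyclobutyl group, which has a four-membered ring of carbon only, would read on the same sulfur.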